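Methyl for Chloro, Repeated on a Second Core

The source may hold more compounds than are shown below. What is called first, only, known or untested is meant among the compounds shown, and "the series" means these compounds.

Four compounds are considered here, all measured or to be measured in an assay on CHO cells for binding affinity to Melanocortin receptor 4 (Homo sapiens); on this read-out lower numbers stand for stronger inhibition and higher numbers for weaker inhibition. Compound 1 `COc1ccc(-n2nc(Sc3ccc(Cl)cc3)cc(CC[C@@H](C)NC(=O)[C@H]3CNCC[C@@H]3c3ccc(Cl)cc3)c2=O)cc1` gives 2.4 nM in this assay. Compound 2 `COc1ccc(-n2nc(Sc3ccc(Cl)cc3)cc(CC[C@@H](C)NC(=O)[C@H]3CNCC[C@@H]3c3ccc(C)cc3)c2=O)cc1` differs from compound 1 by one change, (methyl in place of chloro on an aromatic carbon), and compound 2 gives 4.7 nM. The step of a 2.0-fold higher number from compound 1 to compound 2 (0.29 log units; within the scatter) is therefore small, and the two values are treated as equivalent.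

Compound 3 `COc1ccc(-n2nc(Sc3ccc(Cl)cc3)cc(CC[C@@H](C)NC(=O)[C@H]3CNC[C@@H]3c3ccc(Cl)cc3)c2=O)cc1` carries a different core; how the core of compound 3 differs from the core of compound 1 is not broken down here. In this assay compound 3 gives 45 nM, the highest of the three measured numbers.

Compound 4 `COc1ccc(-n2nc(Sc3ccc(Cl)cc3)cc(CC[C@@H](C)NC(=O)[C@H]3CNC[C@@H]3c3ccc(C)cc3)c2=O)cc1` has not yet been measured. It stands to compound 3 as compound 2 stands to compound 1: the change is methyl in place of chloro on an aromatic carbon, and the place description reads the same in both pairs, so it is taken as the same change applied to a second core. Going by the values given here, the only precedent is the step from compound 1 to compound 2, which lay within the usual scatter. On that basis compound 4 is expected to sit close to compound 3, with a step of roughly a 1.8-fold higher number from compound 3 to compound 4 (0.25 log units; within the scatter), resting on the size of a 2.0-fold higher number from compound 1 to compound 2 (0.29 log units; within the scatter). Among the compounds with values here, the estimate for compound 4 in this assay is 80 nM, with a range from 35 nM to 200 nM; this is an expectation, since a change of core could shift how the substitution behaves, and only one precedent exists.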

Compound 4, half-maximal inhibitory concentration: 28 nM
Estimate against measurement, compound 4: 2.9-fold (0.46 log units) above; measured number outside the range, below it.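

In this assay the new step is a 1.6-fold lower number from compound 3 to compound 4 (0.21 log units; within the scatter), so replacing 4-chlorophenyl with 4-methylphenyl makes only a small difference on the second core, as it did on the core of compound 1. Set side by side, however, the two steps do not match, and the change does not carry over as one fixed step: the same change on two cores in this assay, a 2.0-fold higher number (0.29 log units; within the scatter) from compound 1 to compound 2 and a 1.6-fold lower number (0.21 log units; within the scatter) from compound 3 to compound 4, 3.1-fold (0.50 log units) apart, beyond the scatter of two such steps. Going by these compounds alone, this shows that the change stayed within the scatter on each of these two cores taken singly, but that the size and direction of the step seen on one core should not be transferred exactly to the other; with only two pairs, it does not show why the steps differ or whether the same gap would appear on any further core.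

The compounds shown leave open whether a methoxy, trifluoromethyl or fluoro group in place of chloro would also give closely similar numbers on both cores, or would separate them more clearly. They also leave open whether the gap between the steps belongs to methyl and chloro alone or would recur with other groups at this place on the aromatic ring.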